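The compounds below may be only part of what the source reports. "The series", "measured", "known", "first", "only" and "open" are said of these compounds alone.

Compound 2 `NC(=O)CC[C@H](NC(=O)CN(c1nc(Cl)nc2[nH]cnc12)C1CC1)C(=O)O` — 17.8%
Compound 1 `O=C(CN(c1nc(Cl)nc2[nH]cnc12)C1CC1)N[C@@H](CC(=O)OCc1ccccc1)C(=O)OCc1ccccc1` — 12.1%
Compound 3 `NC(=O)CC[C@H](NC(=O)CN(c1nc(Cl)nc2[nH]cnc12)C1CC1)C(=O)OCc1ccccc1` — 36%

In a functional assay on the whole organism (Tail, strain ICR) with Mus musculus as the target, in the tail flick test, with a stated time of 120 min, at a dose of 25 umol/kg by the oral route (on this read-out higher numbers stand for a stronger effect at the one dose given and lower numbers for a weaker effect), compound 2 stands second highest of the three; its gap to compound 1 lies within the scatter, while compound 3 sits clearly higher. Compound 4 `CC(C)C[C@H](NC(=O)CN(c1nc(Cl)nc2[nH]cnc12)C1CC1)C(=O)O` differs from compound 2 in one place: isopropyl in place of carbamoylmethyl on a saturated chain carbon, two bonds along the chain from an amide-type nitrogen and a carbonyl carbon. Going by the values given here, no measured step makes this same change. The steps known, a number 23.9 percentage points higher from compound 1 to compound 3 (beyond the scatter) and a number 18.2 percentage points higher from compound 2 to compound 3 (beyond the scatter), both lead into compound 3 and concern other groups, so they give only a weak guide. A step of modest size or none beyond the scatter is therefore expected in this assay, with the direction uncertain, so a number 2.8 percentage points lower from compound 2 to compound 4 (within the scatter) is estimated. Compound 4 is expected to give about 15%, between 4% and 27%.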

Compound 4, a percentage reported as activity, at one dose (the size of the read-out at that dose, not a potency): 18.7%
For compound 4 the middle estimate is 3.7 percentage points below the measured one; low and high end bracket the measured number.
By their numbers in this assay, from the lowest: compounds 1, 2 and 4 (each within the scatter of the next); then compound 3.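

In this assay, with the free acid kept, exchanging carbamoylmethyl for isopropyl on this saturated chain carbon gives a number 0.9 percentage points higher from compound 2 to compound 4 (within the scatter) and so leaves the read-out within the scatter. The carbamoyl end of the side chain is therefore not needed to hold this level of effect among the free acids, whereas the earlier step at this carbon, a number 23.9 percentage points higher from compound 1 to compound 3 (beyond the scatter), joined benzyl esters and lay beyond the scatter. Nothing given here explains this result.

On these data alone, it remains open whether an amine or a carboxylic acid at the end of this side chain, or a chain longer than isobutyl, would shift the read-out. As far as these compounds go, it is also open whether isopropyl would match carbamoylmethyl once the acid carries a benzyl group, as in compound 3.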